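From 1,3-Thiazol-2-yl to 4-Methoxyphenyl on an Amide Nitrogen

The source may report more compounds than this note shows. Statements on the series, on what has been measured and on what is new or still open speak of the compounds shown alone.

In a functional assay on KB cells (Homo sapiens) for antiproliferative activity, read by sulforhodamine B assay, with a stated time of 3 days (on this read-out higher numbers stand for weaker inhibition of growth and lower numbers for stronger inhibition of growth), compound 1 `O=C(Nc1ccccn1)c1cccc(Nc2ncc(F)c(Nc3ccc(F)cc3)n2)c1` gives 20000 nM, and compound 2 `COc1ccc(N2CCN(C)CC2)cc1Nc1ncc(F)c(Nc2ccc(F)cc2)n1` gives 960 nM. Compound 3 `O=C(Nc1nccs1)c1cccc(Nc2ncc(F)c(Nc3ccc(F)cc3)n2)c1` is reported only as a limit, > 10000 nM. Compound 4 `COc1ccc(NC(=O)c2cccc(Nc3ncc(F)c(Nc4ccc(F)cc4)n3)c2)cc1` changes the group on the amide-type nitrogen: 4-methoxyphenyl in place of 1,3-thiazol-2-yl on an amide-type nitrogen. Within the data shown here, the one measured step at that nitrogen is a step that the limit leaves unreadable from compound 1 to compound 3, so it offers no size to carry over. The nearest readable value is that of compound 1, 20000 nM, and it points to continued weak growth inhibition. No change beyond the usual scatter is therefore expected in this assay, and the estimated move is a step that the limit leaves unreadable from compound 3 to compound 4. Compound 4 is estimated at 12000 nM, with an expected range from 4000 nM to 30000 nM.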

Compound 4, concentration for 50% growth inhibition: > 10000 nM
Compound 4 ended at the assay's limit; the forecaster's own chance of this, stated with the estimate: 40%; the middle value does not contradict the limit.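

Neither the step from compound 3 to compound 4 nor the one from compound 1 to compound 4 can be read in this assay, because compound 3 and compound 4 are reported only as limits: the limit of > 10000 nM in this assay, at which 2 of the 4 values shown sit.

The compounds shown leave open whether 4-methoxyphenyl on the amide-type nitrogen changes growth inhibition at all.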